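This account rests on a few compounds, and the source may have more. Where it says the series, first, only, none or still open, it means among the compounds named here.

Measured so far:
compound 1 `N=C(N)NCCC[C@H](NC(=O)CN(c1ncnc2c1ncn2C1CCCCO1)C1CC1)C(=O)OCc1ccccc1` — 52.4%
compound 2 `CSCC[C@H](NC(=O)CN(c1nc(Cl)nc2[nH]cnc12)C1CC1)C(=O)OCc1ccccc1` — 30.8%

In a functional assay on the whole organism (Tail, strain ICR) with Mus musculus as the target, in the tail flick test, with a stated time of 60 min, at a dose of 25 umol/kg by the oral route (a lower number here means a weaker effect, a higher number a stronger effect of the compound at the dose given), compound 2 gives 30.8%, the lower of the two numbers, while compound 1 gives 52.4%, a gap that lies beyond the usual scatter. Within the data shown here, the two differ in more than one place, so no step between them can be read off. Compound 3 `NCCCC[C@H](NC(=O)CN(c1nc(Cl)nc2[nH]cnc12)C1CC1)C(=O)OCc1ccccc1` is not yet measured; it differs from compound 2 in a single place: 2-aminoethyl in place of methylsulfanyl on a saturated chain carbon, three bonds along the chain from an amide-type nitrogen and a carbonyl carbon. Among the measured compounds shown here, with no measured pair of this kind, the size of the step can only be guessed. The step of a number 9.2 percentage points higher from compound 2 to compound 3 (within the scatter) is expected to be a small rise, possibly not beyond the scatter. Compound 3 is therefore estimated at 40%, with a range from 22% to 60%.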

Compound 3, a percentage reported as activity, at one dose (the size of the read-out at that dose, not a potency): 41.2%
Estimate against measurement, compound 3: 1.2 percentage points below; the range from low to high includes it.
By their numbers in this assay, from the lowest: compound 2; then compound 3; then compound 1.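

In this assay, this position responds to a change of side chain: 2-aminoethyl in place of methylsulfanyl on a saturated chain carbon, three bonds along the chain from an amide-type nitrogen and a carbonyl carbon, gives a number 10.4 percentage points higher from compound 2 to compound 3 (beyond the scatter). Among these compounds, this is the first step that can be read, as the earlier pair differed in more than one place, and the whole side chain here changes from 2-(methylsulfanyl)ethyl to 4-aminobutyl on an unchanged core. Nothing available gives a reason for this step.

One step cannot separate the arrival of the amine from the loss of the sulfur or the longer chain. On these data alone, how a shorter 3-aminopropyl chain or a terminal carboxylic acid would read at this position remains open.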